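The source may report more compounds than this note shows. Statements on the series, on what has been measured and on what is new or still open speak of the compounds shown alone.

Values in a functional assay on HL-60 cells (Homo sapiens) for cytotoxicity, read by luminescence and CellTiter-Glo, with a stated time of 3 days; on this read-out lower numbers stand for stronger inhibition and higher numbers for weaker inhibition:
- compound 1 `N#Cc1ccc(NC(=O)c2ccc(Cl)cc2O)cc1`: 1300 nM
- compound 2 `N#Cc1ccc(NC(=O)c2ccc(-c3cccnc3)cc2O)cc1`: 6660 nM
- compound 3 `COc1ccc(C(=O)Nc2ccc(C#N)cc2)c(O)c1`: 5470 nM

Compound 3 cannot be separated from its nearest neighbour: a 1.2-fold lower number from compound 2 to compound 3 (0.09 log units; within the scatter). The chloro compound stands apart: a 4.2-fold higher number from compound 1 to compound 3 (0.62 log units; beyond the scatter).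

Compound 4 `N#Cc1ccc(NC(=O)c2ccc(-c3ccncc3)cc2O)cc1` has pyridin-4-yl in place of methoxy on an aromatic carbon. Another measured step bears on this change, and it was modest: a 5.1-fold higher number from compound 1 to compound 2 (0.71 log units; beyond the scatter). The exchange of pyridin-3-yl and methoxy, by contrast, stayed within the scatter. Pyridin-4-yl itself has no measured value yet, so the expectation is loose. No step beyond the scatter is expected in this assay: a 1.1-fold higher number from compound 3 to compound 4 (0.04 log units; within the scatter). The estimated value for compound 4 is 6000 nM, with an expected range of 2500 nM to 14000 nM.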

Compound 4, half-maximal inhibitory concentration: 7090 nM
Estimate against measurement, compound 4: 1.2-fold (0.07 log units) below; low and high end bracket the measured number.
By their numbers in this assay, from the lowest: compound 1; then compounds 3, 2 and 4 (each within the scatter of the next).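

In this assay the nitrogen position within the pyridine ring at this place gives no separation (pyridin-4-yl for pyridin-3-yl, a 1.1-fold higher number from compound 2 to compound 4 (0.03 log units; within the scatter)), and pyridin-4-yl and methoxy also stay together (a 1.3-fold higher number from compound 3 to compound 4 (0.11 log units; within the scatter)). Chloro remains the only group here that stands apart from the others, now also against pyridin-4-yl (a 5.5-fold higher number from compound 1 to compound 4 (0.74 log units; beyond the scatter)). No independent data explain this separation.

Going by these compounds, whether the lower number goes with chloro alone or is shared by fluoro, bromo or methyl at this position remains open. So does the response to an amine or a carboxylic acid here.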